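A few compounds are considered here, and "the series" means these few. Any claim that something is new, unique, unknown or untested is made for them only; others in the source may bear on it.

Compound 1 `CCc1ccc(N2C(=O)C=CC2OCC(F)(F)F)cc1` belongs to a small pair tested in a functional assay on HeLa cells (Homo sapiens) for inhibition; on this read-out lower numbers stand for stronger inhibition and higher numbers for weaker inhibition. In this assay compound 1 gives 6510 nM, the highest of the two numbers shown, while compound 2 `O=C1C=CC(OC(C(F)(F)F)C(F)(F)F)N1c1ccc(Cl)cc1` gives 1890 nM; the two differ in more than one place, so their gap is reported only as what the two values show. Compound 3 `O=C1C=CC(OCC(F)(F)F)N1c1ccc(C(F)(F)F)cc1` has not yet been measured. It differs from compound 1 by trifluoromethyl in place of ethyl on an aromatic carbon. Among the measured compounds shown here, no measured pair shows this change, so only a modest step is expected in this assay, if any beyond the scatter, leaning toward a lower number, as a 1.6-fold lower number from compound 1 to compound 3 (0.21 log units; within the scatter). Compound 3 is therefore estimated at 4000 nM, within 1500 nM to 12000 nM.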

Compound 3, half-maximal inhibitory concentration: 36200 nM
Compound 3: the middle estimate sits 9.1-fold (0.96 log units) below what was measured; measured number outside the range, above it.
By their numbers in this assay, from the lowest: compound 2; then compound 1; then compound 3.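

Among the compounds shown here, putting trifluoromethyl in place of ethyl on an aromatic carbon, para to a large group, is the first change in one place here, and in this assay it gives a 5.6-fold higher number from compound 1 to compound 3 (0.75 log units; beyond the scatter) and so weaker inhibition. This shows that the group at this position matters, even though neither group carries a charge, a hydrogen-bond donor or a hydrogen-bond acceptor. No measured property is available to explain the step. On these data alone, whether a methyl, a methoxy group or an amine at this carbon would give stronger or weaker inhibition than ethyl stays open. So does whether the step would be the same with a different group on the rest of the core.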